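Moving the amide substituent: from compound 3 to compound 4

A few compounds are considered here, and "the series" means these few. Any claim that something is new, unique, unknown or untested is made for them only; others in the source may bear on it.

Compound 3 `O=C(NCc1ccc(CNS(=O)(=O)c2ccccc2)cc1)c1ccccc1F` sits at the weak end of what has been measured in an assay on MDA-MB-231 cells for binding affinity to C-X-C chemokine receptor type 4 (Homo sapiens), read by immunofluorescence and microscopy, with stated times of 10 min and 30 min; on this read-out higher numbers stand for an effect only at larger amounts of compound and lower numbers for an effect already at smaller amounts: compound 3 gives 1000 nM, level with compound 2 `Cc1ccc(S(=O)(=O)NCc2ccc(CNC(=O)c3cccc(C)c3)cc2)cc1`, which gives 1000 nM, while compound 1 `O=C(NCc1ccc(CNS(=O)(=O)c2ccccc2)cc1)c1cccc(F)c1` gives 100 nM, the step of a 10-fold higher number from compound 1 to compound 3 (1.00 log units; beyond the scatter) being the only one known that differs in a single place. Compound 4 `Cc1cccc(C(=O)NCc2ccc(CNS(=O)(=O)c3ccccc3)cc2)c1` differs from compound 3 by 3-methylphenyl in place of 2-fluorophenyl on a carbonyl carbon. For the measured compounds named here, the one step that bears on this change, a 10-fold higher number from compound 1 to compound 3 (1.00 log units; beyond the scatter), shows that shifting the substituent from the 2-position to the 3-position mattered beyond the scatter, so a lower number for compound 4 is expected; compound 2, which carries the same 3-methylphenyl but a different sulfonamide, tempers that expectation. Compound 4 is therefore estimated at 300 nM, with a range from 100 nM to 1000 nM, a step of a 3.3-fold lower number from compound 3 to compound 4 (0.52 log units; beyond the scatter).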

Compound 4, effective concentration (reported as EC, without a stated level of effect): 1000 nM
Compound 4: the middle estimate sits 3.3-fold (0.52 log units) below what was measured, within the range that was stated.
By their numbers in this assay, from the lowest: compound 1; then compounds 2, 3 and 4 (each within the scatter of the next).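

The exchange of 2-fluorophenyl for 3-methylphenyl on a carbonyl carbon brought no change at the digits printed from compound 3 to compound 4 (within the scatter), and hydrogen in place of methyl on an aromatic carbon brought no change at the digits printed from compound 2 to compound 4 (within the scatter). Methyl in place of fluoro on an aromatic carbon, by contrast, brought a 10-fold higher number from compound 1 to compound 4 (1.00 log units; beyond the scatter), so among these compounds the lower number belongs to the 3-fluorophenyl of compound 1 alone, and 3-methylphenyl does not share it. Nothing shown offers an explanation for this difference. Still open, going by these compounds, is whether chloro, methoxy or a nitrile on that aromatic carbon would match compound 1 or compound 4.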